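The compounds below may be only part of what the source reports. "The series", "measured", "known", "first", "only" and "open" are said of these compounds alone.

Compound 1 `COc1ccc(C23CCC(=O)N2CCCO3)cc1` and compound 2 `O=C1CCC2(c3ccc(Cl)cc3)OCCCN12` share a cyclised core. In a functional assay on the whole organism with Mus musculus as the target, in the maximal electroshock model (a higher number here means that more compound is needed for the effect, a lower number that less compound is needed), compound 2 gives 58 mg/kg, and compound 1 gives 93.8 mg/kg. The step of a 1.6-fold higher number from compound 2 to compound 1 (0.21 log units; within the scatter) corresponds to methoxy in place of chloro on an aromatic carbon. Compound 3 `O=C(CCC(=O)c1ccc(Cl)cc1)NCCCO` is the ring-opened counterpart; the difference between the cores of compound 2 and compound 3 is not broken down here. In this assay compound 3 gives > 300 mg/kg, which is a limit of the assay and not a number. Compound 4 `COc1ccc(C(=O)CCC(=O)NCCCO)cc1` is still to be measured in this assay and differs from compound 3 by methoxy in place of chloro on an aromatic carbon, the same change as that from compound 2 to compound 1. The expected step is a step that the limit leaves unreadable from compound 3 to compound 4, resting on a 1.6-fold higher number from compound 2 to compound 1 (0.21 log units; within the scatter). Compound 4 is therefore expected near 400 mg/kg, and a limit is again likely because of the limit of > 300 mg/kg in this assay, at which 1 of the 3 values shown sits.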

Compound 4, dose for half-maximal effect: > 600 mg/kg
Compound 4 was reported as a limit; the forecaster's own chance of this, stated with the estimate: 75%; middle value at least 1.5-fold (0.17 log units) from the limit.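

In this assay, going by these compounds alone, compound 3 and compound 4 both stand as limits of the assay and not as numbers, so no step between them can be read. Open remains whether methoxy in place of chloro gives the ring-opened pair a step like that between compound 2 and compound 1.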